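Half-life notes: phenoxy in place of phenyl

The source may report more compounds than this note shows. Statements on the series, on what has been measured and on what is new or still open speak of the compounds shown alone.

Measured in a physicochemical assay for pharmacokinetics (a higher number here means that the compound lasts longer, a lower number that the compound disappears faster), so far:
- compound 1 `O=C(c1ccccc1)N1C(=O)c2ccccc2S1(=O)=O` gives > 0.875 h
- compound 2 `O=C(c1ccccc1)N1Cc2ccccc2S1(=O)=O` gives > 166 h

Compound 1 stands only at a limit, > 0.875 h, and not at a number. Compound 2 likewise gives only a limit, > 166 h. Within the data shown here, no measured step connects compounds.

Compound 3 `O=C(Oc1ccccc1)N1C(=O)c2ccccc2S1(=O)=O` carries phenoxy in place of phenyl on a carbonyl carbon. A modest upward change in this assay is expected, with the estimated step that the limit leaves unreadable from compound 1 to compound 3. This expectation is loose, as the only anchor is the limit of compound 1. For compound 3 the estimated half-life is 2 h, with an expected range of 0.4 h to 15 h.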

Compound 3, half-life: > 3.04 h
Compound 3: a limit, no number (the forecaster's own chance of this, stated with the estimate: 25%); middle value at least 1.5-fold (0.18 log units) from the limit.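

In this assay, among these compounds, compound 1 and compound 3 both give only limits, and no step between them can be read. Going by these compounds, whether phenoxy in place of phenyl on a carbonyl carbon changes the half-life remains open.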